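Swapping the pyridyl ring for cyclohexyl in a sigma-1 series

A few compounds are considered here, and "the series" means these few. Any claim that something is new, unique, unknown or untested is made for them only; others in the source may bear on it.

Three compounds share one core and differ only in the group attached to it. Compound 1 `O=c1cc(-c2ccccc2Cl)oc2ccc(OCCCCCCN3CCC(O)CC3)cc12` carries a 2-chlorophenyl group, compound 2 `COc1ccc(-c2cc(=O)c3cc(OCCCCCCN4CCC(O)CC4)ccc3o2)cc1` a 4-methoxyphenyl group, and compound 3 `O=c1cc(-c2ccncc2)oc2ccc(OCCCCCCN3CCC(O)CC3)cc12` a pyridin-4-yl group. In an assay on isolated protein (Cavia porcellus) with Sigma non-opioid intracellular receptor 1 (Homo sapiens) as the target, read by radioligand binding (a higher number here means a weaker inhibitor, a lower number a stronger inhibitor), compound 1 gives 47 nM, compound 2 gives 254 nM, and compound 3 gives 159 nM. Compound 3 thus stands second highest of the three: the step of a 1.6-fold lower number from compound 2 to compound 3 (0.20 log units; within the scatter) lies within the scatter, whereas the step of a 3.4-fold higher number from compound 1 to compound 3 (0.53 log units; beyond the scatter) and the step of a 5.4-fold higher number from compound 1 to compound 2 (0.73 log units; beyond the scatter) are modest but real.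

Compound 4 `O=c1cc(C2CCCCC2)oc2ccc(OCCCCCCN3CCC(O)CC3)cc12` is the next step: cyclohexyl in place of pyridin-4-yl on an aromatic carbon. Going by the values given here, no measured step covers an exchange of an aromatic ring for a saturated one, so the measured steps bear on it only loosely. Among the compounds with values here, they show that changing the attached ring moves the number by modest amounts, and that the lowest number so far belongs to compound 1 with a ring free of acceptors. On that basis compound 4 is expected to give a lower number than compound 3, by a modest step, a 2.3-fold lower number from compound 3 to compound 4 (0.36 log units; beyond the scatter). The estimate for compound 4 in this assay is therefore 70 nM, within a range from 25 nM to 200 nM.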

Compound 4, half-maximal inhibitory concentration: 88 nM
Beside the measured number, compound 4's estimate is 1.3-fold (0.10 log units) below it; low and high end bracket the measured number.
By their numbers in this assay, from the lowest: compounds 1, 4, 3 and 2 (each within the scatter of the next, the first and the last beyond it).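

In this assay, going by these compounds alone, a saturated ring of carbon only is tolerated on this aromatic carbon, something the earlier compounds, all with aromatic rings here, could not show: the exchange gives a 1.8-fold lower number from compound 3 to compound 4 (0.26 log units; within the scatter) and, against the best of the aromatic groups, a 1.9-fold higher number from compound 1 to compound 4 (0.27 log units; within the scatter), so cyclohexyl cannot be told apart from pyridin-4-yl or from 2-chlorophenyl. Only the comparison with the 4-methoxyphenyl group separates, at a 2.9-fold lower number from compound 2 to compound 4 (0.46 log units; beyond the scatter), which means that within these four compounds an aromatic ring at this position is not needed for a number close to the lowest one seen, and that losing the ring nitrogen and its hydrogen-bond acceptor in this exchange shifts the number by no more than repeat measurements would. Nothing available here explains why these groups rank as they do.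

The compounds shown carry only six-membered rings at this position, so smaller or open groups such as cyclopropyl or tert-butyl, or a ring bearing an amine such as piperidin-4-yl, remain open. Also open, going by these compounds, is whether cyclohexyl keeps this standing when the other arm of the shared core is changed, for example to a shorter chain.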